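The source may hold more compounds than are shown below. What is called first, only, known or untested is meant among the compounds shown, and "the series" means these compounds.

Compound 1 `CCC(C)Nc1cc(Oc2c(OC)cc3cc(C#N)ccc3c2OC)nc(Nc2ccc(C#N)cc2)n1` opens the series. In an ADME assay on MT4 cells (Homo sapiens) for cytotoxicity, read by MTT assay, with a stated time of 5 days (a higher number here means that more compound is tolerated, a lower number that less compound is tolerated), compound 1 reaches only the limit > 125000 nM. Compound 2 `CCCC(C)Nc1cc(Oc2c(OC)cc3cc(C#N)ccc3c2OC)nc(Nc2ccc(C#N)cc2)n1` is its close partner. In this assay compound 2 likewise stops at the limit > 125000 nM. The step that the two limits leave unreadable from compound 1 to compound 2 has no readable size because of the limit of > 125000 nM in this assay, at which 2 of the 2 values shown sit. Compound 3 `COc1cc2cc(C#N)ccc2c(OC)c1Oc1cc(NC2CCOCC2)nc(Nc2ccc(C#N)cc2)n1` differs from compound 2 by oxan-4-yl in place of 1-methylbutyl on a nitrogen on an aromatic ring. Going by the values given here, no measured step informs this change in this assay, and both values seen sit at a limit. Compound 3 is accordingly expected to stay near that limit, with an estimated 125000 nM (range 60000 nM to 250000 nM) and an expected step of a number no higher from compound 2 to compound 3 (the limit leaves the size open) of nothing beyond the scatter.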

Compound 3, half-maximal cytotoxic concentration: > 125000 nM
Compound 3 gave a limit, no number; the forecaster's own chance of this, stated with the estimate: 75%; the middle value sits exactly at the limit.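

No step can be read among compound 1, compound 2 and compound 3 in this assay, as all three stop at a limit: the limit of > 125000 nM in this assay, at which 3 of the 3 values shown sit.
Going by these compounds, whether sec-butyl, 1-methylbutyl and oxan-4-yl differ at all in this assay stays open.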